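This account rests on a few compounds, and the source may have more. Where it says the series, first, only, none or still open, it means among the compounds named here.

In a physicochemical assay for solubility (on this read-out lower numbers stand for lower solubility and higher numbers for higher solubility), compound 1 (`CNC(=O)c1cc(C(=O)N[C@H]2[C@@H]3C[C@H](O)C[C@@H]32)cc2c1OC[C@@]2(C)c1ccccc1`) stands at >= 151 ug/mL, which is a limit of the assay and not a number. Compound 2 (`CNC(=O)c1cc(C(=O)NC2CC2)cc2c1OC[C@H]2c1cccc(F)c1`) likewise gives only a limit, >= 175 ug/mL. Compound 3 (`CNC(=O)c1cc(C(=O)N[C@H]2C[C@@H]2C)cc2c1OC[C@@]2(CO)c1ccccc1`) also gives only a limit, >= 229 ug/mL. Compound 4 (`CNC(=O)c1cc(C(=O)NC)c2c(c1)[C@](C)(c1ccccc1)CO2`) has not yet been measured. It differs from compound 1 in one place, on an amide-type nitrogen: one carbon atom in place of a group of 7 heavy atoms (6 carbon, 1 oxygen; one three-membered non-aromatic ring of carbon only, one five-membered non-aromatic ring of carbon only), on an amide-type nitrogen. Within the data shown here, the measured compounds offer no step to size this change, so no shift beyond the usual scatter is expected. The estimated step is a number no higher from compound 1 to compound 4 (the limit leaves the size open). For compound 4 the estimated value is 150 ug/mL, with an expected range of 75 ug/mL to 260 ug/mL.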

Compound 4, solubility: >= 132 ug/mL
Compound 4 was reported as a limit; the forecaster's own chance of this, stated with the estimate: 55%; the middle value lies beyond the limit too.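

Compound 1 and compound 4 both stand only as limits in this assay, and the step between them cannot be read. The compounds shown leave open how far each true solubility lies past its limit.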